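A chloro group on the phenyl ring of compound 2

This account rests on a few compounds, and the source may have more. Where it says the series, first, only, none or still open, it means among the compounds named here.

Values measured in a functional assay on U-373MG ATCC cells (Homo sapiens) for inhibition, read by MTT assay, with a stated time of 72 h; on this read-out lower numbers stand for stronger inhibition and higher numbers for weaker inhibition
- compound 1 `CC1(C)CC(NC(=S)Nc2ccc(C#N)cc2)c2cc(Cl)ccc2O1` gives 10000 nM
- compound 2 `CC1(C)CC(NC(=O)Nc2ccccc2)c2cc(Cl)ccc2O1` gives 68000 nM
- compound 3 `CC1(C)CC(NC(=O)NS(=O)(=O)c2ccccc2)c2cc(Cl)ccc2O1` gives 96000 nM

Compound 2 at 68000 nM lies within the usual scatter of compound 3 at 96000 nM. Compound 1 at 10000 nM has a lower number than either, and its gap to compound 2 is beyond the scatter.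

Compound 4 `CC1(C)CC(NC(=O)Nc2ccc(Cl)cc2)c2cc(Cl)ccc2O1` is compound 2 with chloro in place of hydrogen on an aromatic carbon, para to a large group (chloro in place of hydrogen on an aromatic carbon). Going by the values given here, no measured pair shows this change alone. Compound 1 at 10000 nM also has a substituted phenyl ring, but it differs elsewhere too, so this is slim support. A modest fall in the number is expected in this assay (estimated a 2.3-fold lower number from compound 2 to compound 4 (0.36 log units; beyond the scatter)). The estimate for compound 4 is 30000 nM (expected range 10000 nM to 80000 nM).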

Compound 4, half-maximal inhibitory concentration: 19000 nM
Compound 4: middle estimate off by 1.6-fold (0.20 log units), on the high side; the range from low to high includes it.
By their numbers in this assay, from the lowest: compounds 1 and 4 (each within the scatter of the next); then compounds 2 and 3 (each within the scatter of the next).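

In this assay, going by these compounds alone, chloro in place of hydrogen on the phenyl ring gives a 3.6-fold lower number from compound 2 to compound 4 (0.55 log units; beyond the scatter) and provides the first comparison here in which only one place changes. It shows that this aromatic carbon, para to a large group, is a position where a single added atom moves the number beyond the usual scatter.

On these data alone, whether a fluoro, methyl or methoxy group at the same carbon would lower the number as well remains open. Nothing measured here explains why chloro has this effect.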